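Changing the Chain-End Aryl Group: Compound 2 to Compound 3

The source may hold more compounds than are shown below. What is called first, only, known or untested is meant among the compounds shown, and "the series" means these compounds.

Measured so far:
compound 1, `O=C(CCCCCCc1cccnc1)c1ncc(-c2ccccn2)o1`, 32 nM
compound 2, `O=C(CCCCCCc1ccc(Cl)cc1)c1ncc(-c2ccccn2)o1`, 2.7 nM

In an assay for inhibition of Fatty-acid amide hydrolase 1 (Rattus norvegicus) (on this read-out lower numbers stand for stronger inhibition and higher numbers for weaker inhibition), compound 2 holds the lowest of the two numbers shown; the only neighbour is compound 1, which stands a 12-fold lower number from compound 1 to compound 2 (1.07 log units; beyond the scatter) away. Compound 3, `O=C(CCCCCCc1cccc(Cl)c1Cl)c1ncc(-c2ccccn2)o1`, is not yet measured. It differs from compound 2 in one place: 2,3-dichlorophenyl in place of 4-chlorophenyl on a saturated chain carbon, six bonds along the chain from a carbonyl carbon. Among the compounds with values here, the single measured step, a 12-fold lower number from compound 1 to compound 2 (1.07 log units; beyond the scatter), bears on this change only loosely: it shows that the aryl group at the end of the chain can move the read-out strongly, but it compares a pyridin-3-yl with a 4-chlorophenyl, not one chlorophenyl pattern with another. With no closer comparison, a step of modest size in either direction is expected, plausibly a small loss, as a step of a 1.9-fold higher number from compound 2 to compound 3 (0.27 log units; within the scatter). Compound 3 is therefore estimated at 5 nM, within a range of 1.5 nM to 20 nM.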

Compound 3, inhibition constant: 0.9 nM
For compound 3 the middle estimate is 5.6-fold (0.74 log units) above the measured one; the whole stated range lies above it.
By their numbers in this assay, from the lowest: compound 3; then compound 2; then compound 1.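

In this assay, the aryl group at the end of the chain could still move the read-out once a chlorophenyl was in place: 2,3-dichlorophenyl in place of 4-chlorophenyl gave a 3.0-fold lower number from compound 2 to compound 3 (0.48 log units; beyond the scatter) and so went further than the earlier gain over pyridin-3-yl. Taken against pyridin-3-yl directly, the same end group gave a 36-fold lower number from compound 1 to compound 3 (1.55 log units; beyond the scatter) at this position, and both of its steps lie beyond the scatter. No evidence at hand accounts for this gain.

Going by these compounds, compound 2 and compound 3 differ both in the number of chlorines and in where they sit, so the share of each in the step stays open. On these data alone, how an unsubstituted phenyl, a methoxyphenyl or a longer chain would read in this assay also remains open.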